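A few compounds are considered here, and "the series" means these few. Any claim that something is new, unique, unknown or untested is made for them only; others in the source may bear on it.

Compound 1 `COc1cc(NC(C)CCCNC(=O)NNC(=O)Nc2cccc(F)c2)c2ncccc2c1`, compound 2 `COc1cc(NC(C)CCCNC(=O)NNC(=O)Nc2cc(C(F)(F)F)cc(C(F)(F)F)c2)c2ncccc2c1` and compound 3 `COc1cc(NC(C)CCCNC(=O)Nc2ccc(O)cc2)c2ncccc2c1` share one core and differ only in the group on the amide-type nitrogen whose other neighbour is a carbonyl carbon. In a functional assay on CCRF-CEM cells (Homo sapiens) for inhibition, read by MTT assay, with a stated time of 72 h (on this read-out lower numbers stand for stronger inhibition and higher numbers for weaker inhibition), compound 1 gives 98000 nM, compound 2 gives 13000 nM and compound 3 gives 23000 nM. Compound 3 thus holds the second highest of the three numbers; its nearest neighbour is compound 2, which sits within the scatter, and its furthest is compound 1. The one measured step among these is a 4.3-fold lower number from compound 1 to compound 3 (0.63 log units; beyond the scatter).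

Compound 4 `COc1cc(NC(C)CCCNC(=O)NNC(=O)Nc2ccc(F)cc2)c2ncccc2c1` has not yet been measured in this assay. Relative to compound 3 the change is ((4-fluorophenyl)carbamoyl)amino in place of 4-hydroxyphenyl on an amide-type nitrogen. Going by the values given here, this runs the only relevant step backwards: a 4.3-fold lower number from compound 1 to compound 3 (0.63 log units; beyond the scatter) gave a modest drop in the number when ((3-fluorophenyl)carbamoyl)amino was replaced by 4-hydroxyphenyl, and compound 4 restores a group of the same kind, now ((4-fluorophenyl)carbamoyl)amino. Compound 2 shows only that a different substitution on that ring can land within the scatter of compound 3. A rise of roughly that size is therefore expected for compound 4, a 3.0-fold higher number from compound 3 to compound 4 (0.48 log units; beyond the scatter). In this assay compound 4 is expected to give 70000 nM, with a range from 25000 nM to 200000 nM.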

Compound 4, half-maximal inhibitory concentration: 118000 nM
Estimate against measurement, compound 4: 1.7-fold (0.23 log units) below; the measured number falls inside the stated range.
By their numbers in this assay, from the lowest: compounds 2 and 3 (each within the scatter of the next); then compounds 1 and 4 (each within the scatter of the next).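

On an amide-type nitrogen whose other neighbour is a carbonyl carbon, ((4-fluorophenyl)carbamoyl)amino in place of 4-hydroxyphenyl gives a 5.1-fold higher number from compound 3 to compound 4 (0.71 log units; beyond the scatter) in this assay and so places the gap between these two kinds of group on a second pair of compounds, not on compound 1 alone. The place of the fluorine on the ring makes no readable difference here: 4-fluorophenyl in place of 3-fluorophenyl gives a 1.2-fold higher number from compound 1 to compound 4 (0.08 log units; within the scatter) and leaves compound 1 and compound 4 at one level within the scatter. Nothing measured here accounts for the gap between the fluorophenyl carbamoyl groups and 4-hydroxyphenyl.

Still open, as far as these compounds go, is whether the carbamoylamino link or the group on the ring carries the step from compound 3 to compound 4, which a 4-hydroxyphenyl on that link or a 4-fluorophenyl directly on the nitrogen would separate. From the compounds shown here alone, how an amine or a carboxylic acid on that ring would read in this assay also remains open.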